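Loss of the ring hydroxy group on the way to compound 4

A few compounds are considered here, and "the series" means these few. Any claim that something is new, unique, unknown or untested is made for them only; others in the source may bear on it.

Compound 3 `N#CC1=C(N)N(c2ccc(S(N)(=O)=O)cc2)C2=C(C(=O)CCC2)C1c1ccc(O)cc1` is the reference point. In a functional assay on Ehrlich cells (Mus musculus) for antiproliferative activity, read by trypan blue exclusion, with a stated time of 2 h, tested at 25 ug/mL (on this read-out higher numbers stand for a stronger effect at the one concentration tested and lower numbers for a weaker effect), compound 3 gives 95%, the highest of the three numbers measured; compound 1 `N#CC1=C(N)N(c2ccc(S(N)(=O)=O)cc2)C2=C(C(=O)CCC2)C1c1ccccc1` gives 30% and compound 2 `Cc1ccc(C2C(C#N)=C(N)N(c3ccc(S(N)(=O)=O)cc3)C3=C2C(=O)CCC3)cc1` gives 30%, both well beneath it.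

The measured steps give a consistent reading. From compound 1 to compound 2 the methyl in place of hydrogen on an aromatic carbon gave no change at the digits printed from compound 1 to compound 2 (within the scatter), whereas the hydroxy in place of hydrogen gave a number 65 percentage points higher from compound 1 to compound 3 (beyond the scatter) and the hydroxy in place of methyl gave a number 65 percentage points higher from compound 2 to compound 3 (beyond the scatter). On these three compounds the high number goes with the hydroxy group alone.

Compound 4 `N#CC1=C(N)N(c2ccc(S(N)(=O)=O)cc2)C2=C(C(=O)CCC2)C1/C=C/c1ccccc1` differs from compound 3 as follows: 2-phenylethenyl in place of 4-hydroxyphenyl on a saturated ring carbon. The hydroxy group that separates compound 3 from compound 1 and compound 2 is gone, and nothing with a donor or acceptor takes its place. The two steps that bear on this, a number 65 percentage points higher from compound 1 to compound 3 (beyond the scatter) and a number 65 percentage points higher from compound 2 to compound 3 (beyond the scatter), were both large, so a large fall is expected in this assay, roughly undoing them. The expected step is a number 60 percentage points lower from compound 3 to compound 4 (beyond the scatter), and compound 4 is estimated at 35%, with a range from 15% to 65%.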

Compound 4, a percentage reported as activity, at one concentration (the size of the read-out at that concentration, not a potency): 10%
For compound 4 the middle estimate is 25 percentage points above the measured one; measured number below the stated range.
By their numbers in this assay, from the lowest: compound 4; then compounds 1 and 2 (each within the scatter of the next); then compound 3.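

Compounds 1 and 2 looked like a floor for groups without a hydroxy group, but in this assay the result goes below that level, with a number 20 percentage points lower from compound 1 to compound 4 (beyond the scatter) and a number 20 percentage points lower from compound 2 to compound 4 (beyond the scatter) both beyond the scatter. For the compounds shown here, the group on the saturated ring carbon therefore moves the number even when no hydroxy group is involved, and the 2-phenylethenyl group, which sets its aromatic ring further out through a double bond, sits at the low end of the four compounds, with a number 85 percentage points lower from compound 3 to compound 4 (beyond the scatter) as the widest step so far. No measurement on hand accounts for either the modest or the large fall.

The compounds shown do not separate the double bond from the added length, which a saturated 2-phenylethyl group at the same carbon would address, nor do they show whether a hydroxy group on the ring of the 2-phenylethenyl group would recover the high number. Going by these compounds, it also remains open whether the hydroxy group of compound 3 can be replaced on its aromatic ring by an amine, a methoxy group or a carboxylic acid.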